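Swapping Amino for Piperazinyl on a Soluble Thienopyrimidine Core

A few compounds are considered here, and "the series" means these few. Any claim that something is new, unique, unknown or untested is made for them only; others in the source may bear on it.

Within the data shown here, compound 2 `CN(C)CCCNc1nc(N)nc2cc(-c3ccc(C(F)(F)F)cc3)sc12` is the only compound here with a numeric reading: in a physicochemical assay for solubility, at pH 2 (a lower number here means a less soluble compound, a higher number a more soluble compound), compound 2 gives 210 ug/mL. Compound 1 `CNc1nc(Nc2cccc(S(C)(=O)=O)c2)c2sc(-c3ccc(C(F)(F)F)cc3)cc2n1` returns < 5 ug/mL, which is a limit of the assay and not a number, placing it at the limit of < 5 ug/mL in this assay, at which 1 of the 2 values shown sits. Compound 3 `CN(C)CCCNc1nc(N2CCNCC2)nc2cc(-c3ccc(C(F)(F)F)cc3)sc12` differs from compound 2 by one change: piperazin-1-yl in place of amino on an aromatic carbon. Among the measured compounds shown here, no measured pair shows this change, so the expected step from compound 2 to compound 3 in this assay is a modest rise, estimated as a 1.7-fold higher number from compound 2 to compound 3 (0.22 log units; within the scatter). For compound 3 the expected solubility is 350 ug/mL, within a range of 120 ug/mL to 1000 ug/mL.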

Compound 3, solubility: 198 ug/mL
Compound 3: middle estimate off by 1.8-fold (0.25 log units), on the high side, and the stated range covers the measured number.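

Read in this assay, piperazin-1-yl in place of amino on this aromatic carbon, between two ring nitrogen atoms, gives a 1.1-fold lower number from compound 2 to compound 3 (0.03 log units; within the scatter). A six-membered non-aromatic ring can therefore stand at this position with no step beyond the scatter, something compound 2 alone could not show. Nothing measured here explains why the two readings stay so close.

Open, as far as these compounds go, is whether morpholin-4-yl, a simple dimethylamino group or a carboxylic acid at this position would also stay within the scatter of compound 2.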